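The source may hold more compounds than are shown below. What is called first, only, known or untested is meant among the compounds shown, and "the series" means these compounds.

In a functional assay on A549 cells (Homo sapiens) for antiproliferative activity, read by MTT assay, with a stated time of 72 h (a higher number here means a weaker inhibitor, a lower number a stronger inhibitor), compound 1 `O=C(N/N=C/c1ccccc1)Nc1ccc(Oc2ccnc3[nH]ccc23)c(F)c1` gives 2500 nM. Compound 2 `O=C(N/N=C/c1cccc(Br)c1)Nc1ccc(Oc2ccnc3[nH]ccc23)c(F)c1` carries a bromo where compound 1 has hydrogen on an aromatic carbon, and compound 2 gives 2220 nM. Among the compounds with values here, these are the only two numbers so far, and they lie within the scatter of each other, so compound 2 cannot be ranked apart from compound 1.

The next compound, compound 3 `O=C(N/N=C/c1ccc(Br)cc1)Nc1ccc(Oc2ccnc3[nH]ccc23)c(F)c1`, has the same atoms as compound 2, joined differently: 4-bromophenyl in place of 3-bromophenyl on a carbon with a double bond to nitrogen. In words, 4-bromophenyl stands in place of 3-bromophenyl on a carbon with a double bond to nitrogen.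

Within the data shown here, only one measured step bears on this change, and it bears indirectly. Among the measured compounds shown here, that step, a 1.1-fold lower number from compound 1 to compound 2 (0.05 log units; within the scatter), introduced the bromo and did not move it, so no measurement yet shows what relocating the bromo does. Still, the bromo's arrival left the number within the scatter, which gives no reason to expect a large shift or to favour a direction. The expected step is a 1.0-fold lower number from compound 2 to compound 3 (0.00 log units; within the scatter), with no change anticipated beyond the scatter. Compound 3 is therefore estimated at about 2200 nM, within an expected range of 1000 nM to 4800 nM.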

Compound 3, half-maximal inhibitory concentration: 820 nM
Compound 3: the middle estimate sits 2.7-fold (0.43 log units) above what was measured, and the stated range ends above it.
By their numbers in this assay, from the lowest: compound 3; then compounds 2 and 1 (each within the scatter of the next).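

In this assay, where the bromo sits matters, and the earlier pair could not show this: 4-bromophenyl in place of 3-bromophenyl on a carbon with a double bond to nitrogen gives a 2.7-fold lower number from compound 2 to compound 3 (0.43 log units; beyond the scatter), although adding the bromo as 3-bromophenyl had left the number within the scatter. Against the compound without a bromo, the 4-bromophenyl group gives a 3.0-fold lower number from compound 1 to compound 3 (0.48 log units; beyond the scatter), so among these three compounds a bromo goes with a lower number only as 4-bromophenyl, and compound 2 goes against any broader claim that a bromo alone lowers it. Both steps are modest, and no measurement offered here accounts for the difference between the two bromophenyl groups.

These compounds leave open whether the lower number depends on the bromo itself or would also appear with another group in its place, such as a chloro, a methyl or a methoxy. They also leave open whether the same change would give a similar step on a different core or in another cell line.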